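This account rests on a few compounds, and the source may have more. Where it says the series, first, only, none or still open, it means among the compounds named here.

Working notes on the series. Compound 1 `CCCS(=O)(=O)Nc1ccc(F)c(C(=O)c2n[nH]c3ncc(-c4cccc(F)c4)cc23)c1F`, compound 2 `CCCS(=O)(=O)Nc1ccc(F)c(C(=O)c2n[nH]c3ncc(-c4cccc(C)c4)cc23)c1F` and compound 3 `CCCS(=O)(=O)Nc1ccc(F)c(C(=O)c2n[nH]c3ncc(-c4ccc(S(=O)(=O)NC(C)=O)cc4)cc23)c1F` share one core and differ only in the substituent on the pendant phenyl ring. In an assay for binding affinity to dual specificity mitogen-activated protein kinase kinase 4 (Homo sapiens), read by KINOMEscan, tested at 100 nM (a lower number here means a stronger effect, a higher number a weaker effect of the compound at the concentration tested), compound 1 gives 8.2%, compound 2 gives 15% and compound 3 gives 0.35%. Within the data shown here, the only one-point step measured so far, a number 6.8 percentage points higher from compound 1 to compound 2 (within the scatter), stays within the scatter. Compound 3 holds the smallest number of the three: its distance to compound 1 lies within the scatter, its distance to compound 2 beyond it.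

Compound 4 `CCCS(=O)(=O)Nc1ccc(F)c(C(=O)c2n[nH]c3ncc(-c4ccc(C(=O)O)cc4)cc23)c1F` is not yet measured. Relative to compound 3 it carries carboxy in place of acetylsulfamoyl on an aromatic carbon. Among the measured compounds shown here, no measured step in this set touches that group or that place; the single step at hand concerns methyl against fluoro at a different place and was itself within the scatter, so it offers no handle on direction or size. The structural change does remove the larger group and brings in the smaller one, but nothing measured here says what that does. With no pull either way, the expectation for compound 4 is a value close to that of compound 3, the shift a number 2.7 percentage points higher from compound 3 to compound 4 (within the scatter) in this assay being expected to remain within the scatter. Compound 4 is accordingly estimated at 3%, with a range from 0.2% to 15%.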

Compound 4, a percentage reported as activity, at one concentration (the size of the read-out at that concentration, not a potency): 0.1%
Beside the measured number, compound 4's estimate is 2.9 percentage points above it; the whole stated range lies above it.
By their numbers in this assay, from the lowest: compounds 4, 3, 1 and 2 (each within the scatter of the next, the first and the last beyond it).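

In this assay, acetylsulfamoyl gives way to the smaller carboxy on this aromatic carbon, para to a large group, with a number 0.3 percentage points lower from compound 3 to compound 4 (within the scatter), so keeping the read-out low at this place does not depend on the larger group. The wider comparisons separate: replacing 3-methylphenyl with 4-carboxyphenyl gives a number 14.9 percentage points lower from compound 2 to compound 4 (beyond the scatter), beyond the scatter, whereas replacing 3-fluorophenyl with 4-carboxyphenyl gives a number 8.1 percentage points lower from compound 1 to compound 4 (within the scatter), within it, and in both steps the substituent and its place on the pendant phenyl ring change together. The series carries no measurement that would explain any of these steps.

As far as these compounds go, it remains open whether a primary amide, a methyl ester or an amine at the same place would stay as low as carboxy and acetylsulfamoyl, and whether 3-carboxyphenyl would match 4-carboxyphenyl, which would separate the effect of the group from that of its place on the ring. With one tested concentration, the read-out also leaves open whether compound 3 and compound 4 differ in potency.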